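A Smaller Group in Place of the One on Compound 2

The source may report more compounds than this note shows. Statements on the series, on what has been measured and on what is new or still open speak of the compounds shown alone.

Measured so far in a functional assay (aorta) with Rattus norvegicus as the target, in the presence of a further agent that is not named here; on this read-out lower numbers stand for an effect already at smaller amounts and higher numbers for an effect only at larger amounts of compound:
compound 1 `COC(=O)C1=C(C)N=C(C)/C(=C(/O)OC)C1c1cccc(OCc2c(C)no[n+]2[O-])c1` gives 400 nM
compound 2 `COC(=O)C1=C(C)N=C(C)/C(=C(/O)OC)C1c1cccc(OCc2c(C(N)=O)no[n+]2[O-])c1` gives 1200 nM

Going by the values given here, compound 2, at 1200 nM in this series, holds the higher of the only two numbers available. Compound 3 `COC(=O)C1=C(C)N=C(C)/C(=C(/O)OC)C1c1cccc(OCc2nonc2C#N)c1` has not yet been measured. It keeps the shared core and differs from compound 2 in one place: a group of 7 heavy atoms (3 carbon, 3 nitrogen, 1 oxygen; one five-membered aromatic ring with 3 hetero atoms) in place of a group of 9 heavy atoms (3 carbon, 3 nitrogen, 3 oxygen; one five-membered aromatic ring with 3 hetero atoms), on a saturated chain carbon bound to an oxygen on an aromatic ring (the entering group being 4-cyano-1,2,5-oxadiazol-3-yl).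

Among the compounds with values here, only one measured step bears on this change, and it is an indirect guide: a 3.0-fold higher number from compound 1 to compound 2 (0.48 log units; beyond the scatter) came from carbamoyl in place of methyl on an aromatic carbon. That step was modest, though beyond the scatter. Compound 3 has no carbamoyl either, and compound 1, which also lacks it, gave 400 nM as its value. Within the data shown here, no measured compound carries the entering group, however, so the direction is only a lean and the range stays wide. A modest move to a lower number is expected, estimated as a 2.0-fold lower number from compound 2 to compound 3 (0.30 log units; within the scatter) for this pair. Compound 3 is therefore estimated at 600 nM with an expected range from 150 nM to 2400 nM in all.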

Compound 3, half-maximal effective concentration: 310 nM
For compound 3 the middle estimate is 1.9-fold (0.29 log units) above the measured one; the range from low to high includes it.
By their numbers in this assay, from the lowest: compounds 3 and 1 (each within the scatter of the next); then compound 2.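

In this assay, putting 4-cyano-1,2,5-oxadiazol-3-yl on the saturated chain carbon bound to an oxygen on an aromatic ring, in place of the group of compound 2, gives a 3.9-fold lower number from compound 2 to compound 3 (0.59 log units; beyond the scatter) and so shows that the higher number of compound 2 is not fixed by the shared core. The same entering group, set against the group of compound 1, gives a 1.3-fold lower number from compound 1 to compound 3 (0.11 log units; within the scatter) and so shows that two different five-membered aromatic rings at this place can give numbers that cannot be told apart, while the group of compound 2 stands apart from both. Nothing available here accounts for these numbers.

The compounds shown leave open how much of the step to compound 3 belongs to the nitrile and how much to the rest of the exchanged group, since the whole group changes in that step. They also leave open how a carboxylic acid, an amine or a longer chain would read in place of the nitrile on this ring.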